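From methylamino to a fused bicyclic amine on the shared core

The source may hold more compounds than are shown below. What is called first, only, known or untested is meant among the compounds shown, and "the series" means these compounds.

compound 1 `Cn1ccc2cc(-c3ccc4oc(Nc5cccnc5)nc4c3)ccc21`: 226 nM
compound 2 `CNc1nc2cc(-c3ccc4c(ccn4C)c3)ccc2o1`: > 1000 nM

In an assay on HEK293 cells for inhibition of Fatty-acid amide hydrolase 1 (Homo sapiens), read by fluorescence (on this read-out higher numbers stand for weaker inhibition and lower numbers for stronger inhibition), compound 1 gives 226 nM. For compound 2 this assay reports only a limit, > 1000 nM (the limit of > 1000 nM in this assay, at which 1 of the 2 values shown sits). Within the data shown here, the single measured step, an at least 4.4-fold higher number from compound 1 to compound 2 (0.64 log units; beyond the scatter), shows that the larger aromatic substituent on the nitrogen gives the lower number. Compound 3 `Cn1ccc2cc(-c3ccc4oc(N5Cc6ccncc6C5)nc4c3)ccc21` differs from compound 2 by a group of 9 heavy atoms (7 carbon, 2 nitrogen; one five-membered non-aromatic ring with 1 hetero atom, one six-membered aromatic ring with 1 hetero atom) in place of a group of 2 heavy atoms (1 carbon, 1 nitrogen; no ring), on an aromatic carbon. That step does not repeat the measured one, but it again enlarges the group on this position, so a return toward the lower number is expected, estimated as an at least 2.2-fold lower number from compound 2 to compound 3 (0.34 log units; beyond the scatter). Compound 3 is thus expected at 450 nM, between 100 nM and 3000 nM.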

Compound 3, half-maximal inhibitory concentration: 121 nM
For compound 3 the middle estimate is 3.7-fold (0.57 log units) above the measured one, within the range that was stated.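

A second ring-bearing group on this aromatic carbon also gives a lower number than methylamino (an at least 8.2-fold lower number from compound 2 to compound 3 (0.91 log units; beyond the scatter)). As far as these compounds go, that step starts from a limit of the assay, so its full size stays unknown: the limit of > 1000 nM in this assay, at which 1 of the 3 values shown sits. The two ring-bearing groups, though differently built, cannot be told apart (a 1.9-fold lower number from compound 1 to compound 3 (0.27 log units; within the scatter)). The compounds shown leave open whether the aromatic ring within these groups is needed at all, which a saturated amine such as piperidine or morpholine on this carbon would test. A plain dimethylamino group would likewise show whether any ring is required.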